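Notes on the step from compound 2 to compound 4

The source may report more compounds than this note shows. Statements on the series, on what has been measured and on what is new or still open speak of the compounds shown alone.

Measured so far in a functional assay on HCT-15 cells (Homo sapiens) for cytotoxicity, in the presence of a further agent that is not named here; on this read-out lower numbers stand for stronger inhibition and higher numbers for weaker inhibition:
- compound 1, `Clc1ccc(-c2cc(-c3cccnc3)nc(-c3cccs3)c2)o1`: compound 1 gives 1240 nM
- compound 2, `Cc1cccc(-c2cc(-c3ccc(Cl)o3)cc(-c3ccsc3)n2)c1`: compound 2 gives 21700 nM
- compound 3, `Cc1ccc(-c2cc(-c3ccoc3)cc(-c3ccsc3)n2)cc1`: compound 3 gives 44800 nM

Compound 2 holds the second highest of the three numbers in this assay. Its nearest neighbour on the scale is compound 3, whose number lies higher by a margin beyond the usual scatter; compound 1 sits far lower, by a wide margin. No two of these compounds differ in a single place, so no measured step can be read off between them, and the three values only frame the range the series has covered so far.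

Compound 4, `Clc1cccc(-c2cc(-c3ccc(Cl)o3)cc(-c3ccsc3)n2)c1`, differs from compound 2 in one place: chloro in place of methyl on an aromatic carbon. Put one bond further out, the change reads 3-methylphenyl to 3-chlorophenyl, the rest of the shared core staying as in compound 2.

Within the data shown here, for this change no measured pair gives guidance. The expectation is a small step in this assay from compound 2 to compound 4, most likely toward a somewhat lower number, yet possibly no step beyond the scatter; the expected step is a 1.4-fold lower number from compound 2 to compound 4 (0.16 log units; within the scatter). Compound 4 is therefore estimated at 15000 nM, within a range from 5000 nM to 50000 nM.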

Compound 4, half-maximal inhibitory concentration: 13700 nM
Beside the measured number, compound 4's estimate is 1.1-fold (0.04 log units) above it; the range from low to high includes it.
By their numbers in this assay, from the lowest: compound 1; then compounds 4 and 2 (each within the scatter of the next); then compound 3.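

In this assay, among these compounds, chloro in place of methyl on an aromatic carbon, meta to a large group, gives the first step that can be read in one place: a 1.6-fold lower number from compound 2 to compound 4 (0.20 log units; within the scatter). On this read-out, 3-methylphenyl and 3-chlorophenyl are therefore not separated at this position, at least on the shared core of this pair, where one single heavy atom replaces another and neither group carries a hydrogen-bond donor or acceptor. Nothing measured here bears on why the two groups read alike.

The compounds shown leave open whether this position stays as flat for groups of a different kind, such as an amine, a carboxylic acid or a longer chain, and whether the same exchange of methyl for chloro would read the same way on another core. Steps at the other places of the shared core cannot be read from these compounds, so the parts of the structure that govern the number in this assay remain unassigned.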